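The source may report more compounds than this note shows. Statements on the series, on what has been measured and on what is new or still open speak of the compounds shown alone.

The account follows one change along the saturated chain that joins a carbonyl to an aromatic ring. Compound 1 `O=C(CCCCCCc1ccccc1)c1ncc(-c2ccccc2F)o1` is one of two measured compounds. In an assay on HEK-293T cells for inhibition of diacylglycerol lipase-alpha (Homo sapiens), read by colorimetric assay (a higher number here means a weaker inhibitor, a lower number a stronger inhibitor), compound 1 reaches only a limit of the assay, giving > 10000 nM. Compound 1 therefore sits at the limit of > 10000 nM in this assay, at which 1 of the 2 values shown sits. Compound 2 `O=C(CCCc1ccccc1)c1nc2ncccc2o1` shares its core with the unmeasured compound 3 and, in this assay, compound 2 gives 2240 nM, the only finite number shown. Compound 3 `O=C(CCCCc1ccccc1)c1nc2ncccc2o1` differs from compound 2 by benzyl in place of phenyl on a saturated chain carbon, three bonds along the chain from a carbonyl carbon. Going by the values given here, no measured pair shows this change, so its size is open from the data. Compound 3 is expected to show a step of a 1.2-fold lower number from compound 2 to compound 3 (0.09 log units; within the scatter), which would remain within the usual scatter. The estimate for compound 3 in this assay is 1800 nM, with a range from 500 nM to 6000 nM.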

Compound 3, half-maximal inhibitory concentration: 204 nM
Estimate against measurement, compound 3: 8.8-fold (0.95 log units) above; measured number below the stated range.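

The result shows that this position on the chain is not indifferent: on the core shared by compound 2 and compound 3, benzyl in place of phenyl gives, in this assay, an 11-fold lower number from compound 2 to compound 3 (1.04 log units; beyond the scatter), a step beyond the scatter. Going by these compounds alone, this is the only step that can be read, so the effect of this change is known from a single pair on a single core. Nothing in the data shown accounts for the size of this step.

From the compounds shown here alone, whether a longer chain on this shared core would lower the number further or raise it again remains open, as does the effect of an amine or a carboxylic acid at the end of the chain. Within the data shown here, compound 1 differs from both other compounds in more than one place, so no step to it can be read.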